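The source may report more compounds than this note shows. Statements on the series, on what has been measured and on what is new or still open speak of the compounds shown alone.

Working notes on the series.

Within the data shown here, compound 2 `CC(C)C(c1noc(=O)[nH]1)c1ccc(-c2ccc3cccc(F)c3c2)[nH]c1=O` gives 41 nM in a functional assay on CHO cells for antagonist activity at prostaglandin E2 receptor EP3 subtype (Homo sapiens), read by cAMP accumulation (a lower number here means a stronger inhibitor, a higher number a weaker inhibitor), the highest of the three numbers measured so far. Compound 3 `CCC(CC)(c1nnc[nH]1)c1ccc(-c2ccc3cccc(F)c3c2)[nH]c1=O` gives 36 nM, within the scatter of compound 2; compound 1 `CC(C)NC(=O)CC(c1ccc(-c2ccc3cccc(F)c3c2)[nH]c1=O)C(C)C` gives 15 nM, the lowest of the three and beyond the scatter from compound 2. Among the measured compounds shown here, the one single-point step measured is a 2.7-fold higher number from compound 1 to compound 2 (0.44 log units; beyond the scatter), where a ring with three hetero atoms replaced a group with no ring on the saturated chain carbon.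

Compound 4 `CC(C)C(Cc1nnc[nH]1)c1ccc(-c2ccc3cccc(F)c3c2)[nH]c1=O` is the next point. Relative to compound 2 the change is a group of 6 heavy atoms (3 carbon, 3 nitrogen; one five-membered aromatic ring with 3 hetero atoms) in place of a group of 6 heavy atoms (2 carbon, 2 nitrogen, 2 oxygen; one five-membered aromatic ring with 3 hetero atoms), on a saturated chain carbon bound to an aromatic carbon and a saturated chain carbon. For the measured compounds named here, no measured step exchanges one five-membered aromatic ring with 3 hetero atoms for another on this carbon; compound 3 also carries such a ring there, but it differs from compound 2 in more than one place, so only its two values can be set side by side, and they lie within the scatter of each other. Given that, a small step in this assay from compound 2 to compound 4 is expected, if any, with no firm direction; a slightly lower number is taken as the centre because compound 3 gives 36 nM. The estimated step is a 1.3-fold lower number from compound 2 to compound 4 (0.11 log units; within the scatter). Compound 4 is expected at 32 nM, with a range of 12 nM to 85 nM.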

Compound 4, half-maximal inhibitory concentration: 17 nM
Beside the measured number, compound 4's estimate is 1.9-fold (0.27 log units) above it, within the range that was stated.
By their numbers in this assay, from the lowest: compounds 1 and 4 (each within the scatter of the next); then compounds 3 and 2 (each within the scatter of the next).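

Among these compounds, on the saturated chain carbon bound to an aromatic carbon and a saturated chain carbon, (4H-1,2,4-triazol-3-yl)methyl in place of the ring with two oxygens gives a 2.4-fold lower number from compound 2 to compound 4 (0.38 log units; beyond the scatter) in this assay, the first exchange here of one five-membered aromatic ring with 3 hetero atoms for another, and it lies beyond the scatter. With 4H-1,2,4-triazol-3-yl in place of isopropylcarbamoyl on a saturated chain carbon, two bonds along the chain from an aromatic carbon, the result is a 1.1-fold higher number from compound 1 to compound 4 (0.05 log units; within the scatter), so a ring and a group with no ring are not told apart at this place in this pair. The higher number in a 2.7-fold higher number from compound 1 to compound 2 (0.44 log units; beyond the scatter) therefore does not extend to every five-membered aromatic ring with 3 hetero atoms on this carbon, as compound 4 goes against it.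

The step from compound 2 to compound 4 changes both the ring atoms and the methyl link, and the compounds shown do not separate the two. Going by these compounds, whether a carboxylic acid or a primary amine carried on the same methyl link would stay with compound 1 and compound 4 also remains open. No measurement in hand gives a reason for either step.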